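The source may report more compounds than this note shows. Statements on the series, on what has been measured and on what is new or still open speak of the compounds shown alone.

Compound 1 `COc1ccc(/C=C/C(=O)NC(CCN(C)C)c2ccc(C)cc2)cc1` stands lowest of the three measured compounds: in a functional assay on NIH3T3 cells for agonist activity at Urotensin-2 receptor (Homo sapiens), with a stated time of 5 days (a higher number here means a larger maximal response, a lower number a smaller maximal response), compound 1 gives 79%, compound 2 `COc1ccc(/C=C/C(=O)NC(CCN(C)C)c2ccc3ccccc3c2)cc1` gives 106%, and compound 3 `CN(C)CCC(NC(=O)/C=C/c1ccc(C(F)(F)F)cc1)c1ccc2ccccc2c1` gives 117%. The change from compound 1 to compound 4 `COc1ccc(/C=C/C(=O)NC(CCN(C)C)c2ccc(Cl)cc2)cc1` is chloro in place of methyl on an aromatic carbon. Going by the values given here, no measured step involves a chloro in place of methyl, so nothing bears on it directly. Among the compounds with values here, the only measured step, a number 11 percentage points higher from compound 2 to compound 3 (beyond the scatter), exchanged one group for another on an aromatic carbon and was modest. A step of similar or smaller size is therefore expected here, and the estimated step of a number 6 percentage points higher from compound 1 to compound 4 (within the scatter) is a slight rise that may well stay within the scatter. Compound 4 is expected to give about 85%, with a range from 70% to 102%.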

Compound 4, largest response reached (reported as efficacy), in percent of the reference or control that the assay uses: 99%
Beside the measured number, compound 4's estimate is 14 percentage points below it, within the range that was stated.
By their numbers in this assay, from the lowest: compound 1; then compounds 4 and 2 (each within the scatter of the next); then compound 3.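

At this position, on an aromatic carbon para to a large group, the change from 4-methylphenyl to 4-chlorophenyl gives a number 20 percentage points higher from compound 1 to compound 4 (beyond the scatter) in this assay. So the maximal response can shift with a single exchanged group, even though methyl and chloro each count one heavy atom, no ring and no hydrogen-bond donors or acceptors. No measurement here explains why the response shifts.

From the compounds shown here alone, how a fluoro, a bromo or a nitrile at this same position would compare with chloro remains open. So does whether an amine there would keep the response.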